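The source may hold more compounds than are shown below. What is called first, only, known or untested is meant among the compounds shown, and "the series" means these compounds.

Compounds measured so far:

Compound 1, `CCCNC(=O)C1CCN(C(=O)c2cc3sc(Br)cc3n2Cc2ccc(OC)cc2)CC1`: in an ADME assay on HEK-293T cells (Homo sapiens) for cytotoxicity, read by luminescence, with a stated time of 24 h (on this read-out higher numbers stand for lower toxicity in this test and lower numbers for higher toxicity in this test), compound 1 gives > 100000 nM, which is a limit of the assay and not a number.
Compound 2, `CCCNC(=O)C1CCN(C(=O)c2cc3sc(CNC(C)c4ccccc4)cc3n2Cc2ccc(OC)cc2)CC1`: in this assay compound 2 gives 33900 nM.

Going by the values given here, compound 2 therefore holds the only true number so far, the other entry being a limit. The step from the bromo compound to the aminomethyl compound gave an at least 2.9-fold lower number from compound 1 to compound 2 (0.46 log units; beyond the scatter), so compound 2 is read as more toxic than compound 1 in this test, the comparison resting on (the limit of > 100000 nM in this assay, at which 1 of the 2 values shown sits).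

Compound 3, `CCCNC(=O)C1CCN(C(=O)c2cc3sc(-c4ccccc4)cc3n2Cc2ccc(OC)cc2)CC1`, has not been measured yet. It differs from compound 2 by phenyl in place of ((1-phenylethyl)amino)methyl on an aromatic carbon. Among the compounds with values here, the only measured step that bears on this change is the one from compound 1 to compound 2, which swapped the group at the same position and moved the number beyond the scatter. Compound 3 keeps an aromatic ring there but loses the donor and acceptor that entered with the aminomethyl group, so compound 3 is expected to move back toward the bromo compound, with a step of a 1.8-fold higher number from compound 2 to compound 3 (0.25 log units; within the scatter) in this assay. The estimate for compound 3 in this assay is 60000 nM, expected to fall between 20000 nM and 150000 nM.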

Compound 3, half-maximal cytotoxic concentration: > 100000 nM
Compound 3 gave a limit, no number; the forecaster's own chance of this, stated with the estimate: 35%; at least 1.6-fold (0.22 log units) between middle value and limit.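

Placing phenyl instead of ((1-phenylethyl)amino)methyl on the aromatic carbon next to the ring sulfur gives an at least 2.9-fold higher number from compound 2 to compound 3 (0.46 log units; beyond the scatter) in this assay, so compound 3 reads as less toxic in this test than compound 2. The step from compound 1 to compound 2 alone could not tell whether any six-membered aromatic ring of carbon only at this carbon would go with a lower number, and compound 3 now gives one case where such a ring does not, while the nitrogen and the carbons linking the ring to the core are gone. Compound 1 and compound 3 both sit at a limit of the assay, not at a number, so the step between them cannot be read and the step from compound 2 to compound 3 gives only a minimum size: the limit of > 100000 nM in this assay, at which 2 of the 3 values shown sit.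

Going by these compounds, it remains open whether the lower number of compound 2 goes with the nitrogen itself or with the whole ((1-phenylethyl)amino)methyl group. A benzyl group, which keeps a linking carbon but has no nitrogen, or a plain aminomethyl group, which has a nitrogen but no phenyl ring, would help to separate these two readings.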